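The source may hold more compounds than are shown below. What is called first, only, known or untested is meant among the compounds shown, and "the series" means these compounds.

Three compounds that share one core were tested in an ADME assay on the whole organism with Oryza sativa as the target, tested at 1 uM; a higher number here means a weaker effect of the compound at the concentration tested, a lower number a stronger effect. Compound 1, `C[C@H](NC(=O)Nc1cccc(F)c1)c1ccccc1`, gives 94% there. Compound 2, `C[C@H](NC(=O)Nc1ccc(F)cc1)c1ccccc1`, gives 97%. Compound 3, `C[C@@H](NC(=O)Nc1ccc(F)c(F)c1)c1ccccc1`, gives 99%. This is the highest of the three numbers, yet both other readings lie within the usual scatter of it: compound 2 sits closest and compound 1 furthest away, and neither gap is large enough to count as a real difference. On the numbers shown, the three compounds therefore look alike, each with only a weak effect at the concentration used.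

Compound 4, `C[C@H](NC(=O)Nc1ccc(F)c(F)c1)c1ccccc1`, has not yet been measured. Compared with compound 3, it differs as follows: the two compounds have the same atoms and bonds and differ only in configuration as drawn: 1 of 1 stereo elements differ; a stereocentre at a saturated chain carbon is drawn R in compound 3 and S in compound 4. Going by the values given here, no pair of measured compounds that differ in one place exists here, so there is no measured step to lean on. With compound 3 at 99% and the other two readings within the scatter of it, the expected step of a number 3 percentage points lower from compound 3 to compound 4 (within the scatter) is one that stays within the scatter, with no direction foreseen beyond it. The value for compound 4 in this assay is estimated at 96%, most likely between 86% and 102%.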

Compound 4, a percentage reported as activity, at one concentration (the size of the read-out at that concentration, not a potency): 100%
Compound 4: the middle estimate sits 4 percentage points below what was measured, and the stated range covers the measured number.
By their numbers in this assay, from the lowest: compounds 1, 2, 3 and 4 (each within the scatter of the next).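

In this assay, the drawn configuration at the saturated chain carbon can now be compared directly, and the change gives a number 1 percentage points higher from compound 3 to compound 4 (within the scatter), so on these numbers the two forms cannot be told apart. That comparison speaks to the stereocentre alone, with nothing else in the structure changing alongside it: the fact that compounds 3 and 4 differ only in the configuration as drawn. The same holds for the aromatic ring, where fluoro in place of hydrogen gives a number 3 percentage points higher from compound 2 to compound 4 (within the scatter) and, starting from the other singly fluorinated compound, a number 6 percentage points higher from compound 1 to compound 4 (within the scatter), so neither added fluoro produces a real difference at the position tested.

All four compounds read close together at the weak end of this assay, which leaves open whether the configuration or the fluoro pattern would matter in a compound with a clearly stronger effect. The aromatic ring here carries only fluoro, and the chain at the stereocentre stays the same throughout, so the compounds shown say nothing about a methoxy group, a nitrile, a carboxylic acid or a longer chain in those places.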